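A few compounds are considered here, and "the series" means these few. Any claim that something is new, unique, unknown or untested is made for them only; others in the source may bear on it.

Measured so far in a functional assay on HCT-15 cells (Homo sapiens) for antiproliferative activity, read by MTT assay, with a stated time of 72 h; a lower number here means a stronger inhibitor, a higher number a weaker inhibitor (both entries are limits of the assay, not numbers):
- Compound 1 `COc1cc(-c2nccn2C)cc(OC)c1OC` gives > 100000 nM
- Compound 2 `COc1cc(-c2nccn2CC(C)C)cc(OC)c1OC` gives > 100000 nM

Compound 2 therefore has no exact value and stands only at a limit (the limit of > 100000 nM in this assay, at which 2 of the 2 values shown sit). Compound 3 `CCCCCn1ccnc1-c1cc(OC)c(OC)c(OC)c1` has butyl in place of isopropyl on a saturated chain carbon bound to an aromatic nitrogen. Among the measured compounds shown here, the one measured step that bears on this change is a step that the two limits leave unreadable from compound 1 to compound 2 and it offers no size to carry over. No step beyond the scatter is therefore expected in this assay, in either direction, and compound 3 will most likely also be reported only as a limit. The estimate for compound 3 is 100000 nM (expected range 30000 nM to 150000 nM). That estimate means a number no higher from compound 2 to compound 3 (the limit leaves the size open) as the expected step.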

Compound 3, half-maximal inhibitory concentration: > 100000 nM
Compound 3 gave a limit, no number; the forecaster's own chance of this, stated with the estimate: 75%; the middle value sits exactly at the limit.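

No step can be read among compound 1, compound 2 and compound 3, because all three are reported only as a limit, not as a number: the limit of > 100000 nM in this assay, at which 3 of the 3 values shown sit. The compounds shown leave open how active each one really is in this assay, and so whether butyl in place of isopropyl makes any difference.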